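Aminomethyl variation at the aryl substituent of the urea series

The source may report more compounds than this note shows. Statements on the series, on what has been measured and on what is new or still open speak of the compounds shown alone.

Measured so far:
- compound 1, `CC(C)N(CCN(C(=O)Nc1ccc(F)c(Cl)c1)C1CC[C@]2(c3cccc(C#N)c3)CC2C1)C(C)C`: 4.98 nM
- compound 2, `CC(C)N(CCN(C(=O)Nc1ccc(F)c(Cl)c1)C1CC[C@]2(c3cccc(CN4CC[C@H](O)C4)c3)CC2C1)C(C)C`: 21 nM

In a functional assay for antagonist activity at melanin-concentrating hormone receptor 1 (Homo sapiens) (a higher number here means a weaker inhibitor, a lower number a stronger inhibitor), compound 1 gives 4.98 nM and compound 2 gives 21 nM. For the measured compounds named here, compound 2 stands at the higher of the two numbers, its only neighbour being compound 1; the step of a 4.2-fold higher number from compound 1 to compound 2 (0.62 log units; beyond the scatter) is the one measured step in the set.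

Compound 3, `CCN(CC)Cc1cccc([C@]23CCC(N(CCN(C(C)C)C(C)C)C(=O)Nc4ccc(F)c(Cl)c4)CC2C3)c1`, differs from compound 2 by diethylamino in place of 3-hydroxypyrrolidin-1-yl on a saturated chain carbon bound to an aromatic carbon. Going by the values given here, no measured step covers an exchange of one aminomethyl group for another; the step of a 4.2-fold higher number from compound 1 to compound 2 (0.62 log units; beyond the scatter) replaces a cyano group and so bears only loosely on the change. Compound 3 is therefore expected to stay near compound 2, with a step of a 1.2-fold lower number from compound 2 to compound 3 (0.07 log units; within the scatter) not beyond the scatter. For compound 3 the estimate in this assay is 18 nM, within a range from 6 nM to 55 nM.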

Compound 3, inhibition constant: 46 nM
Estimate against measurement, compound 3: 2.6-fold (0.41 log units) below; low and high end bracket the measured number.
By their numbers in this assay, from the lowest: compound 1; then compound 2; then compound 3.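

In this assay, the choice of amine on this methyl linker matters, not only the replacement of the nitrile: diethylamino in place of 3-hydroxypyrrolidin-1-yl on a saturated chain carbon bound to an aromatic carbon gives a change beyond the scatter (a 2.2-fold higher number from compound 2 to compound 3 (0.34 log units; beyond the scatter)). The comparison with the nitrile widens accordingly (a 9.2-fold higher number from compound 1 to compound 3 (0.97 log units; beyond the scatter)), so both aminomethyl groups give weaker inhibition than the nitrile, and they also differ from each other. No supporting measurement accounts for the difference between the two amines, and the pair cannot separate the ring from the hydroxyl.

Going by these compounds, whether an unsubstituted pyrrolidin-1-yl, morpholin-4-yl or dimethylamino group would fall nearer compound 2 or compound 3 remains open. Also open, on these data alone, is whether a primary aminomethyl group or a carboxylic acid at this aromatic carbon would approach compound 1 (4.98 nM).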